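The compounds below may be only part of what the source reports. "The series", "measured", "known", "first", "only" and "open" are said of these compounds alone.

Measured so far:
Compound 1, `CCO[C@H]1C[C@@H](c2coc3ccc(Br)cc3c2=O)N(c2ccccc2)O1`, gives > 60000 nM in a functional assay on Caco-2 cells (Homo sapiens) for inhibition, read by sulforhodamine B assay, with a stated time of 48 h; a higher number here means a weaker inhibitor, a lower number a stronger inhibitor; this is a limit of the assay, not a number.
Compound 2, `O=c1c([C@@H]2C[C@H](c3ccccc3)ON2c2ccccc2)coc2ccc(F)cc12`, gives 60000 nM in this assay.
Compound 3, `COC(=O)[C@@]1(C)C[C@@H](c2coc3ccc(F)cc3c2=O)N(c2ccccc2)O1`, gives 29500 nM in this assay.

Of the two values that are numbers, compound 2 stands highest. Its nearest neighbour is compound 3, whose number is lower by a gap that lies beyond the usual scatter of repeated measurements. Compound 1 sits at the limit of > 60000 nM in this assay, at which 1 of the 3 values shown sits, so it gives no number to compare.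

Compound 4, `Cc1ccc2occ([C@@H]3C[C@H](c4ccccc4)ON3c3ccccc3)c(=O)c2c1`, has not yet been measured in this assay. It differs from compound 2 in one place: methyl in place of fluoro on an aromatic carbon.

For the measured compounds named here, no two measured compounds differ from each other in a single place, so no measured step offers a direct guide to this exchange. The change is small in size, and the step from compound 2 to compound 4 is expected to stay within the scatter, with no clear direction. The estimated step of no change at the digits printed from compound 2 to compound 4 (within the scatter) reflects this expectation.

Compound 4 is therefore expected to give about 60000 nM in this assay, with a range from 25000 nM to 150000 nM. A result reported only as a limit, as for compound 1, is also quite possible for compound 4.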

Compound 4, half-maximal inhibitory concentration: 31700 nM
Compound 4: the middle estimate sits 1.9-fold (0.28 log units) above what was measured, within the range that was stated.
By their numbers in this assay, from the lowest: compounds 3, 4 and 2 (each within the scatter of the next, the first and the last beyond it).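

For the compounds shown here, this is the first step between measured compounds that differ in one place: with methyl in place of fluoro on an aromatic carbon, meta to a fused ring and para to a fused ring, the exchange gives a 1.9-fold lower number from compound 2 to compound 4 (0.28 log units; within the scatter). At this position in this assay, then, the two groups are not told apart, although they are different atoms of the same heavy-atom count, and neither brings a ring, a hydrogen-bond donor, a hydrogen-bond acceptor or a net charge. Going by these compounds alone, the step is read at the upper end of the numbers in this assay, since compound 2 stands highest among them, and the one value that is a limit and not a number belongs to compound 1: the limit of > 60000 nM in this assay, at which 1 of the 4 values shown sits.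

What the compounds shown leave open is whether any group at this position would move the number beyond the scatter, such as an amine, a methoxy group or a carboxylic acid. They also leave open whether methyl and fluoro would still read alike on a core carrying the other substituents of compound 3.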